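Swapping a Morpholine Amide for a Methylamide

The compounds below may be only part of what the source reports. "The series", "measured", "known", "first", "only" and "open" are said of these compounds alone.

Compound 1 `CC[C@H](C)[C@@H]1C(=O)N[C@H](C2Cc3ccccc3C2)C(=O)N1[C@@H](C(=O)N1CCOCC1)c1cnc(C)cc1C` gives 4 mL.min-1.g-1 in an in vitro ADME assay on microsomes from liver (Canis lupus familiaris) for metabolic stability; a lower number here means slower removal, a higher number faster removal of the compound.
Compound 2 `CCC(CC)[C@@H]1C(=O)N[C@H](C2Cc3ccccc3C2)C(=O)N1[C@@H](C(=O)N1CCOCC1)c1ccc(C)nc1` gives 5 mL.min-1.g-1 in this assay.

Among these two numbers compound 1 stands lowest, yet its nearest neighbour, compound 2, lies only a small distance higher, within the usual scatter of this assay, so the two cannot be told apart. Within the data shown here, no pair of measured compounds differs in one place only, and so no single structural step has been measured.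

Compound 3 `CC[C@H](C)[C@@H]1C(=O)N[C@H](C2Cc3ccccc3C2)C(=O)N1[C@@H](C(=O)NC)c1cnc(C)cc1C` differs from compound 1 in one place: methylamino in place of morpholin-4-yl on a carbonyl carbon. The shared core of compound 1 and compound 3 is otherwise unchanged.

Both measured compounds give low numbers in this assay, that is, slow removal. Among the measured compounds shown here, with no measured step to lean on, the change from compound 1 to compound 3 is expected to bring no shift beyond the scatter, and the expected step is no change at the digits printed from compound 1 to compound 3 (within the scatter). Compound 3 is therefore estimated to give 4 mL.min-1.g-1, with a range from 2 mL.min-1.g-1 to 8 mL.min-1.g-1.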

Compound 3, intrinsic clearance in microsomes: 4 mL.min-1.g-1
The estimate for compound 3 equals the measured number at the digits printed; low and high end bracket the measured number.
By their numbers in this assay, from the lowest: compounds 1, 3 and 2 (each within the scatter of the next).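

Among these compounds, this is the first single change measured: in this assay, putting methylamino in place of morpholin-4-yl on a carbonyl carbon gives no change at the digits printed from compound 1 to compound 3 (within the scatter), a result that can now be read directly instead of being inferred from two compounds differing in more than one place. On the core of compound 1, then, the six-membered non-aromatic ring with its 6 heavy atoms can give way to a group of 2 heavy atoms with no ring and 1 hydrogen-bond donor, and the number in this assay still shows slow removal, so the morpholine ring is not required for that outcome on this core. No measurement of any property of these two groups bears on this result, so the data offer no explanation for it.

The compounds shown leave open whether other groups on this carbonyl carbon, such as dimethylamino or a longer chain like n-butylamino, or a carboxylic acid in place of the amide, would also leave the number in this assay unchanged. They also leave open whether the same swap would read the same way on the core of compound 2.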